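Swapping the aryl group of a diaryl thiourea

The compounds below may be only part of what the source reports. "The series", "measured", "known", "first", "only" and "open" are said of these compounds alone.

Compound 1 `CNC(=O)c1ccc(Oc2cccc(NC(=S)Nc3cc(C(F)(F)F)cc(C(F)(F)F)c3)c2)nc1` in a functional assay on MDA-MB-231 cells (Homo sapiens) for antiproliferative activity, read by MTT assay; a higher number here means a weaker inhibitor, a lower number a stronger inhibitor: 2670 nM
Compound 2 `CNC(=O)c1ccc(Oc2cccc(NC(=S)Nc3ccc(C)c(C)c3)c2)nc1` in this assay: 38600 nM
Compound 3 `CNC(=O)c1ccc(Oc2cccc(NC(=S)Nc3ccc(F)c(F)c3)c2)nc1` in this assay: 69300 nM

The three measured compounds share one core and differ only in the aryl group on an amide-type nitrogen. Compound 2 gives the second highest of the three numbers: its nearest neighbour is compound 3, reached by a 1.8-fold higher number from compound 2 to compound 3 (0.25 log units; within the scatter), so the two cannot be told apart; compound 1 stands far off with a much lower number, meaning a stronger inhibitor.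

Compound 4 `CNC(=O)c1ccc(Oc2cccc(NC(=S)Nc3ccc(OC)cc3)c2)nc1` differs from compound 2 in that place: 4-methoxyphenyl in place of 3,4-dimethylphenyl on an amide-type nitrogen.

Among the compounds with values here, only one measured step touches this position, namely a 1.8-fold higher number from compound 2 to compound 3 (0.25 log units; within the scatter), and it lies within the scatter. Within the data shown here, no measured step places an oxygen-bearing group on this ring, so nothing here shows how 4-methoxyphenyl behaves. Compound 1 shows that a change on this ring can move the number strongly, but that change is unlike the present one. The step of a 1.3-fold higher number from compound 2 to compound 4 (0.11 log units; within the scatter) is therefore expected to be small, with no clear direction beyond the scatter, and with wide uncertainty. Compound 4 is estimated at 50000 nM, within a range from 15000 nM to 160000 nM.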

Compound 4, half-maximal inhibitory concentration: 31500 nM
Compound 4: the middle estimate sits 1.6-fold (0.20 log units) above what was measured; measured number inside the range.
By their numbers in this assay, from the lowest: compound 1; then compounds 4, 2 and 3 (each within the scatter of the next, the first and the last beyond it).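

With compound 4, a group carrying an oxygen atom enters this position, and in this assay the step is a 1.2-fold lower number from compound 2 to compound 4 (0.09 log units; within the scatter) so 4-methoxyphenyl and 3,4-dimethylphenyl cannot be told apart here, even though 4-methoxyphenyl brings a hydrogen-bond acceptor that 3,4-dimethylphenyl lacks. Set against 3,4-difluorophenyl, the same group gives a 2.2-fold lower number from compound 3 to compound 4 (0.34 log units; beyond the scatter) which is a modest step that only just clears the scatter, while compounds 2 and 3 stay within the scatter of each other, so these three aryl groups form one loose cluster rather than a clear ranking, with compound 1 at 2670 nM standing apart from them. Nothing measured here accounts for these numbers.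

As far as these compounds go, it remains open whether the much lower number of compound 1 needs both trifluoromethyl groups or would survive with a single trifluoromethyl group, and whether any other aryl group can come close to it. The compounds shown also leave unknown what a chlorine atom, an amine or a carboxylic acid on this ring would do to the number.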